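The source may hold more compounds than are shown below. What is called first, only, known or untested is meant among the compounds shown, and "the series" means these compounds.

Going by the values given here, compound 2 `CCCCc1ncc(CN(CC(=O)O)Cc2ccccc2)n1Cc1ccc(C(=O)O)cc1` stands at the stronger end of the two numbers so far in a functional assay (aorta) for inhibition, with Oryctolagus cuniculus as the target (a lower number here means a stronger inhibitor, a higher number a weaker inhibitor), where compound 2 gives 11 nM. Its nearest neighbour in this assay is compound 1 `CCCCc1ncc(CNCC(=O)O)n1Cc1ccc(C(=O)O)cc1`, and compound 1 gives 335 nM. Among the compounds with values here, the one measured step, a 30-fold lower number from compound 1 to compound 2 (1.48 log units; beyond the scatter), shows how much the benzyl group on the amine nitrogen contributes. Compound 3 `CCCCc1ncc(CN(CC(=O)O)Cc2cccs2)n1Cc1ccc(C(=O)O)cc1` keeps that arrangement and alters only the ring at its end: thiophen-2-yl in place of phenyl on a saturated chain carbon bound to an amine nitrogen. Within the data shown here, no measured pair shows a thiophen-2-yl in place of phenyl, so the step from compound 2 to compound 3 has no direct precedent. Since the large gain from compound 1 to compound 2 came from adding an aromatic ring on that carbon, and compound 3 still carries one, the step is expected to stay within the scatter, a 1.1-fold higher number from compound 2 to compound 3 (0.04 log units; within the scatter). Compound 3 is therefore estimated to give 12 nM in this assay, with a range from 5 nM to 30 nM.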

Compound 3, antagonist equilibrium constant: 2.4 nM
The estimate for compound 3 lay 5.0-fold (0.70 log units) above the measured number; measured number below the stated range.
By their numbers in this assay, from the lowest: compound 3; then compound 2; then compound 1.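

In this assay, the ring at the end of this substituent turns out to matter as well as its presence: thiophen-2-yl in place of phenyl on a saturated chain carbon bound to an amine nitrogen gives a further gain (a 4.6-fold lower number from compound 2 to compound 3 (0.66 log units; beyond the scatter)). Measured against the unsubstituted amine, (thiophen-2-yl)methyl on the nitrogen gives the largest step seen so far (a 140-fold lower number from compound 1 to compound 3 (2.14 log units; beyond the scatter)), which exceeds the step for benzyl (a 30-fold lower number from compound 1 to compound 2 (1.48 log units; beyond the scatter)). Nothing available explains why the thiophen-2-yl compound gives the lower number.

As far as these compounds go, it remains open whether this gain is particular to thiophen-2-yl or is shared by other rings at this place, such as thiophen-3-yl, furan-2-yl or pyridin-2-yl. Also open, from the compounds shown here alone, is how a longer chain between the amine nitrogen and the thiophene ring would fare.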